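Chloroalkyl amide extension on the aryl sulfonate series

A few compounds are considered here, and "the series" means these few. Any claim that something is new, unique, unknown or untested is made for them only; others in the source may bear on it.

Measured so far in a functional assay on M21 cells (Homo sapiens) for antiproliferative activity, read by sulforhodamine B assay, with a stated time of 48 h; a higher number here means a weaker inhibitor, a lower number a stronger inhibitor:
compound 1 `CCC(=O)Nc1ccc(S(=O)(=O)Oc2ccccc2C(C)C)cc1` gives 11000 nM
compound 2 `CCC(=O)Nc1ccc(S(=O)(=O)Oc2ccccc2I)cc1` gives 11000 nM
compound 3 `O=C(CCl)Nc1ccc(S(=O)(=O)Oc2ccccc2I)cc1` gives 3900 nM

Compound 1 stands together with compound 2 at the highest numbers of the three: no change at the digits printed from compound 1 to compound 2 (within the scatter). The only drop is a 2.8-fold lower number from compound 2 to compound 3 (0.45 log units; beyond the scatter).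

Compound 4 `CC(C)c1ccccc1OS(=O)(=O)c1ccc(NC(=O)CCCCl)cc1` differs from compound 1 by chloromethyl in place of hydrogen on a saturated chain carbon, two bonds along the chain from a carbonyl carbon. The step from compound 2 to compound 3 is the one that bears on it, since it also brings a chlorine into the amide chain, though there the chlorine sits on the carbon bound to the carbonyl carbon, whereas here a chloromethyl is added further out. A modest lowering in this assay at most is therefore expected, possibly none beyond the scatter. For compound 4 the expected value in this assay is 7000 nM, estimated range 3000 nM to 18000 nM, which is an expected 1.6-fold lower number from compound 1 to compound 4 (0.20 log units; within the scatter).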

Compound 4, half-maximal inhibitory concentration: 5100 nM
Beside the measured number, compound 4's estimate is 1.4-fold (0.14 log units) above it, and the stated range covers the measured number.
By their numbers in this assay, from the lowest: compounds 3 and 4 (each within the scatter of the next); then compounds 1 and 2 (each within the scatter of the next).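

In this assay, chloromethyl in place of hydrogen on a saturated chain carbon, two bonds along the chain from a carbonyl carbon, gives a 2.2-fold lower number from compound 1 to compound 4 (0.33 log units; beyond the scatter), so a drop beyond the scatter is no longer confined to chlorine on the carbon bound to the carbonyl carbon. It also appears with the isopropyl group of compound 1 rather than the iodo group of compound 2. No evidence at hand accounts for the step.

From the compounds shown here alone, whether the chlorine or the added chain length carries the step remains open. A plain butanoyl amide on the core of compound 1 would separate the two, while a 3-aminopropyl group or a longer chloroalkyl chain would probe the chain end further.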